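Swapping the chlorine position on a pyridine-linked phenyl ring

The source may report more compounds than this note shows. Statements on the series, on what has been measured and on what is new or still open speak of the compounds shown alone.

Compound 1 `Oc1ccc(-c2cc(-c3ccccn3)nc(-c3ccccc3Cl)c2)cc1` carries a hydroxyphenyl group, a pyridin-2-yl group and a 2-chlorophenyl group on a shared core. In a functional assay on T47D cells (Homo sapiens) for cytotoxicity, read by CCK-8 assay and cell counting, with a stated time of 2 days (a lower number here means a stronger inhibitor, a higher number a weaker inhibitor), compound 1 stands at "not determined" (no result reported), so no number anchors it. Two related compounds were measured: compound 2 `Oc1ccc(-c2cc(-c3cccs3)nc(-c3ccccc3Cl)c2)cc1`, which in this assay gives 5870 nM, and compound 3 `Oc1ccc(-c2cc(-c3ccsc3)nc(-c3ccccc3Cl)c2)cc1`, which gives 6110 nM. Among the compounds with values here, the only measured step, a 1.0-fold higher number from compound 2 to compound 3 (0.02 log units; within the scatter), concerns a thiophene swap and not the chlorophenyl group, so it does not bear directly on the change examined here.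

Compound 4 `Oc1ccc(-c2cc(-c3ccc(Cl)cc3)nc(-c3ccccn3)c2)cc1` differs from compound 1 in one place: 4-chlorophenyl in place of 2-chlorophenyl on an aromatic carbon. Within the data shown here, since no measured step covers this change and compound 1 itself has no number, the expectation for compound 4 must rest on the neighbourhood defined by compound 2 and compound 3, whose values sit close together. Compound 4 is therefore estimated at 6000 nM in this assay, with a wide range from 1500 nM to 25000 nM reflecting the missing anchor.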

Compound 4, half-maximal inhibitory concentration: 25900 nM
Beside the measured number, compound 4's estimate is 4.3-fold (0.64 log units) below it; the whole stated range lies below it.
By their numbers in this assay, from the lowest: compounds 2 and 3 (each within the scatter of the next); then compound 4.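

No new step can be read between compound 1 and compound 4, as compound 1 has no number for comparison. Going by these compounds, what 4-chlorophenyl in place of 2-chlorophenyl does in this assay stays open. Nothing shown here offers an explanation for the result of compound 4.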